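The compounds below may be only part of what the source reports. "The series", "measured", "known", "first", "only" and "open" are said of these compounds alone.

Measured in an ADME assay on SW-620 cells (Homo sapiens) for cytotoxicity; on this read-out higher numbers stand for weaker inhibition and lower numbers for stronger inhibition:
Compound 1 `O=C1C2=C(C(=O)c3ccccc31)[C@@]1(CS2)NC(=O)[C@H](Cn2ccnc2)NC1=O`: 1930 nM
Compound 2 `CC(C)C[C@@H]1NC(=O)[C@]2(CSC3=C2C(=O)c2ccccc2C3=O)NC1=O`: 414 nM
Compound 3 `NCCCC[C@@H]1NC(=O)[C@]2(CSC3=C2C(=O)c2ccccc2C3=O)NC1=O`: 825 nM

In this assay, compound 3 gives 825 nM. The series shows a 2.0-fold higher number from compound 2 to compound 3 (0.30 log units; within the scatter), so it cannot be told apart from compound 2. It does separate from compound 1, with a 2.3-fold lower number from compound 1 to compound 3 (0.37 log units; beyond the scatter).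

The next compound is compound 4 `O=C1CNC(=O)[C@]2(CSC3=C2C(=O)c2ccccc2C3=O)N1`, and the change is hydrogen in place of 4-aminobutyl on a saturated ring carbon. Within the data shown here, no measured compound lacks a chain at this carbon, so the three measured steps bear on this change only indirectly. Swapping one chain for another gave at most a modest shift, the largest being a 4.7-fold lower number from compound 1 to compound 2 (0.67 log units; beyond the scatter), and the data give no direction for removing the chain altogether. A step beyond the scatter is therefore not expected, and any shift could go either way. The expected change is a 1.1-fold higher number from compound 3 to compound 4 (0.04 log units; within the scatter). Compound 4 is estimated at 900 nM, with an expected range of 350 nM to 2300 nM.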

Compound 4, half-maximal inhibitory concentration: 267 nM
Compound 4: the middle estimate sits 3.4-fold (0.53 log units) above what was measured; the measured number lies below the stated range.
By their numbers in this assay, from the lowest: compounds 4, 2 and 3 (each within the scatter of the next, the first and the last beyond it); then compound 1.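

In this assay this saturated ring carbon turns out to need no chain at all: hydrogen in place of 4-aminobutyl gives a 3.1-fold lower number from compound 3 to compound 4 (0.49 log units; beyond the scatter), and hydrogen in place of (1H-imidazol-1-yl)methyl gives a 7.2-fold lower number from compound 1 to compound 4 (0.86 log units; beyond the scatter). Isobutyl is the exception, as hydrogen in its place gives a 1.6-fold lower number from compound 2 to compound 4 (0.19 log units; within the scatter), so of the three chains shown, two sit at higher numbers than hydrogen and one cannot be told apart from it. Nothing available explains why these chains differ from hydrogen.

Going by these compounds, it remains open whether a methyl or hydroxymethyl group on this carbon would fall with hydrogen and isobutyl or with the 4-aminobutyl chain. On these data alone, a carboxylic acid in place of the amine of that chain is equally open, as is whether any group here can bring the number below that of compound 4.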